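The compounds below may be only part of what the source reports. "The series", "measured", "known", "first", "only" and "open" are said of these compounds alone.

Compounds measured in an assay for inhibition of 6-phosphofructo-2-kinase/fructose-2,6-bisphosphatase 3 (Homo sapiens), read by ADP-Glo, with a stated time of 2 h; a higher number here means a weaker inhibitor, a lower number a stronger inhibitor:
- compound 1, `Cn1cc(CNC(=O)c2ccncc2Nc2cc(-c3ccc4ccn(C)c4c3)c3nccnc3c2)cn1`: 159 nM
- compound 2, `CC(=O)N1CCC(NC(=O)c2ccncc2Nc2cc(-c3ccc4ccn(C)c4c3)c3nccnc3c2)CC1`: 18 nM
- compound 3, `CN1CC(NC(=O)c2ccncc2Nc2cc(-c3ccc4ccn(C)c4c3)c3nccnc3c2)C1`: 30 nM

Compound 3 stands second highest of the three numbers. Its nearest neighbour is compound 2, a step that lies within the scatter; its furthest is compound 1, and the step from compound 1 to compound 3 was a 5.3-fold lower number from compound 1 to compound 3 (0.72 log units; beyond the scatter). The parallel step from compound 1 to compound 2 was an 8.8-fold lower number from compound 1 to compound 2 (0.95 log units; beyond the scatter), and the step from compound 2 to compound 3 was a 1.7-fold higher number from compound 2 to compound 3 (0.22 log units; within the scatter).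

Compound 4, `CC(=O)N1CC(NC(=O)c2ccncc2Nc2cc(-c3ccc4ccn(C)c4c3)c3nccnc3c2)C1`, has not yet been measured. It differs from compound 3 in one place: acetyl in place of methyl on an amine nitrogen in a ring. Going by the values given here, the only measured step that touches this part of the molecule is the one from compound 2 to compound 3, which exchanges both the ring and the group on its nitrogen at once and stays within the scatter. Among the compounds with values here, no measured step isolates the exchange of methyl for acetyl on the azetidine nitrogen. On this basis, compound 4 is expected to give a number close to that of compound 3, with the expected step of a 1.2-fold lower number from compound 3 to compound 4 (0.08 log units; within the scatter) not reaching beyond the scatter. The estimate for compound 4 in this assay is 25 nM, within a range from 10 nM to 70 nM.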

Compound 4, half-maximal inhibitory concentration: 73 nM
Compound 4: middle estimate off by 2.9-fold (0.47 log units), on the low side; the whole stated range lies below it.
By their numbers in this assay, from the lowest: compounds 2 and 3 (each within the scatter of the next); then compound 4; then compound 1.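

In this assay, the exchange on the azetidine nitrogen can now be read on its own: acetyl in place of methyl on this amine nitrogen gives a 2.4-fold higher number from compound 3 to compound 4 (0.39 log units; beyond the scatter), so the group there affects the result. With acetyl held fixed, the ring also proves to matter, as 1-acetylazetidin-3-yl in place of 1-acetylpiperidin-4-yl gives a 4.1-fold higher number from compound 2 to compound 4 (0.61 log units; beyond the scatter), a difference that the earlier step within the scatter, which exchanged the ring and the group on its nitrogen at once, did not reveal. The 1-acetylazetidin-3-yl group nevertheless still compares well with (1-methyl-1H-pyrazol-4-yl)methyl on the amide-type nitrogen, with a 2.2-fold lower number from compound 1 to compound 4 (0.34 log units; beyond the scatter), although no available evidence accounts for any of these shifts.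

Going by these compounds, what a 1-methylpiperidin-4-yl group on the amide-type nitrogen would give remains open, and with it whether the exchange of methyl for acetyl has the same size on both rings. On these data alone, it is also open whether an ethyl or a methoxycarbonyl group on the azetidine nitrogen would track with methyl or with acetyl.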